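This account rests on a few compounds, and the source may have more. Where it says the series, first, only, none or still open, it means among the compounds named here.

Measured compounds in a functional assay on NCI-H460 cells (Homo sapiens) for cytotoxicity, read by MTT assay, with a stated time of 72 h; on this read-out higher numbers stand for weaker inhibition and lower numbers for stronger inhibition:

Compound 1 `CN(C)CCNc1nc(-c2ccc(NC(=O)Nc3ccccc3F)cc2)nc2ccsc12` — compound 1 gives 410 nM
Compound 2 `CN(C)CCNc1nc(-c2ccc(NC(=O)Nc3ccc(Cl)cc3)cc2)nc2ccsc12` — compound 2 gives 130 nM
Compound 3 `CCN(CC)CCNc1nc(-c2ccc(NC(=O)Nc3ccccc3F)cc2)nc2ccsc12` — compound 3 gives 430 nM

Compound 2 differs from compound 1 by 4-chlorophenyl in place of 2-fluorophenyl on an amide-type nitrogen. That change made a 3.2-fold lower number from compound 1 to compound 2 (0.50 log units; beyond the scatter). Compound 3 differs from compound 1 by diethylamino in place of dimethylamino on a saturated chain carbon, two bonds along the chain from a nitrogen on an aromatic ring, and the step was a 1.0-fold higher number from compound 1 to compound 3 (0.02 log units; within the scatter), so compounds 1 and 3 are read as equivalent in this assay.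

Compound 4 `CCN(CC)CCNc1nc(-c2ccc(NC(=O)Nc3ccc(Cl)cc3)cc2)nc2ccsc12` is not yet measured. It differs from compound 3 by 4-chlorophenyl in place of 2-fluorophenyl on an amide-type nitrogen. This is the same change as that between compound 1 and compound 2, with the same place in both pairs; it occurs twice among these compounds, measured once. The cores of compound 3 and compound 4 differ from those of compound 1 and compound 2 by diethylamino in place of dimethylamino on a saturated chain carbon, two bonds along the chain from a nitrogen on an aromatic ring, and that difference left the number unchanged within the scatter.

Within the data shown here, compound 4 is expected to show a step of a 3.1-fold lower number from compound 3 to compound 4 (0.49 log units; beyond the scatter), close to the step seen from compound 1 to compound 2, because a 3.2-fold lower number from compound 1 to compound 2 (0.50 log units; beyond the scatter) is the only measured instance of this change. The difference in the cores left the number unchanged within the scatter, as a 1.0-fold higher number from compound 1 to compound 3 (0.02 log units; within the scatter) shows. Among the measured compounds shown here, with only one prior instance, the range is kept wide. Compound 4 is estimated at 140 nM, between 60 nM and 320 nM.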

Compound 4, half-maximal inhibitory concentration: 190 nM
Compound 4: the middle estimate sits 1.4-fold (0.13 log units) below what was measured; low and high end bracket the measured number.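

In this assay, the change from 2-fluorophenyl to 4-chlorophenyl on the amide-type nitrogen carries over to the diethylamino core, giving a 2.3-fold lower number from compound 3 to compound 4 (0.35 log units; beyond the scatter), and it agrees with the earlier step on the dimethylamino core: the same change on two cores in this assay, a 3.2-fold lower number (0.50 log units; beyond the scatter) from compound 1 to compound 2 and a 2.3-fold lower number (0.35 log units; beyond the scatter) from compound 3 to compound 4, 1.4-fold (0.14 log units) apart, within the scatter of two such steps
The reverse view of the same square holds as well: diethylamino in place of dimethylamino gives a 1.5-fold higher number from compound 2 to compound 4 (0.16 log units; within the scatter) with 4-chlorophenyl present, which matches the step seen with 2-fluorophenyl present: the same change on two cores in this assay, a 1.0-fold higher number (0.02 log units; within the scatter) from compound 1 to compound 3 and a 1.5-fold higher number (0.16 log units; within the scatter) from compound 2 to compound 4, 1.4-fold (0.14 log units) apart, within the scatter of two such steps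
The two changes therefore read as independent within these four compounds, but the transfer is shown only between two cores that differ in one small amine group and in one assay, so it does not show that the step would hold on a more different core, and it says nothing about why the number moves.

The compounds shown leave open whether the step follows the chlorine or the place of the halogen, which 4-fluorophenyl and 2-chlorophenyl would separate. Also open, as far as these compounds go, is whether the number stays level with a morpholine or a piperidine in place of diethylamino.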